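Difluorophenyl isomers in the series: working notes

This account rests on a few compounds, and the source may have more. Where it says the series, first, only, none or still open, it means among the compounds named here.

Values in an ADME assay on microsomes from liver (Rattus norvegicus) for metabolic stability (on this read-out higher numbers stand for a longer-lived compound and lower numbers for a shorter-lived compound), so far
compound 1 `Cc1cccc(NC(=O)c2nn(C)c(-c3ccccc3)c2C)n1` gives 0.567 h
compound 2 `Cc1cccc(NC(=O)c2nn(C)c(-c3ccc(F)cc3F)c2C)n1` gives 1.27 h

Compound 2 stands highest of the two numbers, at 1.27 h on this read-out. The next case is compound 3 `Cc1cccc(NC(=O)c2nn(C)c(-c3cc(F)cc(F)c3)c2C)n1` and the change is 3,5-difluorophenyl in place of 2,4-difluorophenyl on an aromatic carbon with the same atoms joined differently. In words, 3,5-difluorophenyl takes the place of 2,4-difluorophenyl on an aromatic carbon next to the ring nitrogen.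

For the measured compounds named here, one measured step bears on this: a 2.2-fold higher number from compound 1 to compound 2 (0.35 log units; beyond the scatter) for 2,4-difluorophenyl in place of phenyl. That step is modest but beyond the scatter. Going by the values given here, it compares phenyl with one difluorophenyl only, and no measured pair compares two difluorophenyl groups. No step beyond the scatter is therefore expected in this assay and a slight fall is the more likely direction. The expected step is a 1.3-fold lower number from compound 2 to compound 3 (0.10 log units; within the scatter) and this lies within the scatter. For compound 3 the estimate is 1 h with an expected range from 0.5 h to 2 h on this read-out.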

Compound 3, half-life: 1.07 h
For compound 3 the middle estimate is 1.1-fold (0.03 log units) below the measured one, and the stated range covers the measured number.
By their numbers in this assay, from the lowest: compounds 1, 3 and 2 (each within the scatter of the next, the first and the last beyond it).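

In this assay, the exchange of isomers gives a 1.2-fold lower number from compound 2 to compound 3 (0.07 log units; within the scatter) and so, on this aromatic carbon next to the ring nitrogen, the two difluorophenyl groups cannot be told apart, a comparison that the earlier pair of phenyl and a single difluorophenyl group could not offer. Set against phenyl, the new isomer gives a 1.9-fold higher number from compound 1 to compound 3 (0.28 log units; within the scatter) and so, on the printed steps, only 2,4-difluorophenyl stands clear of phenyl, even though the two difluorophenyl compounds lie within the scatter of each other. Nothing at hand accounts for any of these steps.

The three compounds leave open whether fluorine is needed on the phenyl ring at all for a step beyond the scatter, since a single fluorine, a chlorine, a methoxy group or a nitrile in its place could give a step of any size or direction in this assay and none of these groups is among them. They also leave open whether the small gap between the two isomers would persist on a different core, as all three compounds share one.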